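Swapping the Amine Chain of Compound 3

The compounds below may be only part of what the source reports. "The series", "measured", "known", "first", "only" and "open" are said of these compounds alone.

Measured in a functional assay on HepG2 cells (Homo sapiens) for antiproliferative activity, read by MTT assay, with a stated time of 72 h (a lower number here means a stronger inhibitor, a higher number a weaker inhibitor), so far
- compound 1 `O=C(N/N=C/c1ccc([N+](=O)[O-])cc1)Nc1ccc(Oc2ccnc3[nH]ccc23)c(F)c1` gives 3030 nM
- compound 2 `O=C(N/N=C/c1ccc(Cl)c(Cl)c1)Nc1ccc(Oc2ccnc3[nH]ccc23)c(F)c1` gives 3700 nM
- compound 3 `CN(C)CCn1cccc1/C=N/NC(=O)Nc1ccc(Oc2ccnc3[nH]ccc23)c(F)c1` gives 8980 nM

Compound 3 has the highest number of the three, which makes it the weakest inhibitor so far. Compound 4 `CN1CCN(CCCn2cccc2/C=N/NC(=O)Nc2ccc(Oc3ccnc4[nH]ccc34)c(F)c2)CC1` differs from it only at the end of the side chain, where the change is (4-methylpiperazin-1-yl)methyl in place of dimethylamino on a saturated chain carbon, two bonds along the chain from an aromatic nitrogen and the rest of the molecule stays the same. Read one bond further out, 2-(dimethylamino)ethyl gives way to 3-(4-methylpiperazin-1-yl)propyl.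

Going by the values given here, no measured step touches this side chain on its own, so the available steps bear on the change only loosely. All of them alter the group on the carbon with a double bond to nitrogen. Reaching compound 3 gives the modest steps of a 3.0-fold higher number from compound 1 to compound 3 (0.47 log units; beyond the scatter) and a 2.4-fold higher number from compound 2 to compound 3 (0.39 log units; beyond the scatter) while a 1.2-fold higher number from compound 1 to compound 2 (0.09 log units; within the scatter) stays within the scatter. None of these shows a direction for the new change, so no step beyond the scatter is expected in this assay here. The expected step is a 1.1-fold lower number from compound 3 to compound 4 (0.05 log units; within the scatter) as an estimate only. For compound 4 the estimated value is 8000 nM with an expected range from 3000 nM to 20000 nM in this measurement.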

Compound 4, half-maximal inhibitory concentration: 2740 nM
Compound 4: the middle estimate sits 2.9-fold (0.47 log units) above what was measured, outside the stated range (below it).
By their numbers in this assay, from the lowest: compounds 4, 1 and 2 (each within the scatter of the next); then compound 3.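

In this assay, the far end of the side chain is now shown to matter: with the rest of the molecule unchanged, replacing 2-(dimethylamino)ethyl with 3-(4-methylpiperazin-1-yl)propyl gives a 3.3-fold lower number from compound 3 to compound 4 (0.52 log units; beyond the scatter). Going by these compounds alone, the earlier steps all altered the group on the carbon with a double bond to nitrogen, so this is the first step beyond the scatter that can be tied to this saturated chain, and it points towards stronger inhibition, although the size of the step is only modest. No measurement available here accounts for this step, so the reason for it remains unknown.

This single step changes two things at once, the chain going from ethyl to propyl and the dimethylamino end giving way to a 4-methylpiperazin-1-yl ring, and the compounds shown cannot separate these two changes. A 3-(dimethylamino)propyl chain or a 2-(4-methylpiperazin-1-yl)ethyl chain would tell them apart, while a morpholine ring at the chain end would test whether the second ring nitrogen of the piperazine is needed.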